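Lengthening the Ester Chain on an Imidazole Amide

This account rests on a few compounds, and the source may have more. Where it says the series, first, only, none or still open, it means among the compounds named here.

Two compounds built on the same imidazole-bearing amino ester backbone, each capped with an aromatic amide, have been tested in an assay on HL-60 cells for inhibition of cytochrome P450 26A1 (Homo sapiens), read by HPLC, using microsomes and NADPH, with a stated time of 30 min; a lower number here means a stronger inhibitor, a higher number a weaker inhibitor. Compound 1 `CC(C)COC(=O)C(Cn1ccnc1)NC(=O)c1ccc(-c2ccccc2)cc1` carries a branched ester and a two-ring aromatic amide; in this assay compound 1 gives 970 nM. Compound 2 `COC(=O)C(Cn1ccnc1)NC(=O)c1nc2ccccc2s1` carries a smaller ester and a fused bicyclic amide; in this assay compound 2 gives 410 nM. Of the two numbers, compound 2 holds the lower one, and its gap to compound 1 lies beyond the usual scatter.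

Compound 3 `CCOC(=O)C(Cn1ccnc1)NC(=O)c1nc2ccccc2s1` differs from compound 2 in a single place: methyl in place of hydrogen on a saturated chain carbon bound to an oxygen next to a carbonyl group. Among the compounds with values here, no measured pair shows this exact change, so its effect is unknown. Because compound 2 already reaches 410 nM and the change adds a single carbon on the ester chain, the expected step from compound 2 to compound 3 in this assay is small, a 1.0-fold higher number from compound 2 to compound 3 (0.01 log units; within the scatter), not beyond the scatter in either direction. Compound 3 is therefore estimated to give 420 nM in this assay, with a likely range from 160 nM to 1100 nM.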

Compound 3, half-maximal inhibitory concentration: 740 nM
Compound 3: middle estimate off by 1.8-fold (0.25 log units), on the low side; measured number inside the range.
By their numbers in this assay, from the lowest: compounds 2, 3 and 1 (each within the scatter of the next, the first and the last beyond it).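

Within the data shown here, this pair is the first in this assay that differs in one place only, so the ester can be judged with the amide and the rest of the core held fixed. Replacing methoxycarbonyl with ethoxycarbonyl gives a 1.8-fold higher number from compound 2 to compound 3 (0.26 log units; within the scatter), which means that this one pair does not separate the two esters, and the added methyl on the saturated chain carbon bound to an oxygen next to a carbonyl group can be accommodated without a change that clearly exceeds measurement noise. Nothing available explains the result at this position.

Going by these compounds, whether the same tolerance holds for a longer chain, such as a propyl or butyl ester, or for a carboxylic acid in place of the ester, remains open. Compound 1 does carry a branched isobutyl ester, but it also has a different aromatic amide, so it cannot show what branching alone does when the amide of compound 2 and compound 3 is kept.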